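Replacing piperidin-3-yl with furan-2-yl on the shared core

The source may report more compounds than this note shows. Statements on the series, on what has been measured and on what is new or still open speak of the compounds shown alone.

Among the compounds with values here, in a functional assay on cells (Homo sapiens), read by thymidine incorporation (a lower number here means a stronger inhibitor, a higher number a weaker inhibitor), compound 3 `Brc1cnn2c(NCc3cccnc3)cc(C3CCCNC3)nc12` gives 60 nM as the lowest of the three numbers measured so far. Compound 1 `CCc1cc(NCc2cccnc2)n2ncc(Br)c2n1` carries ethyl at the same place and gives 520 nM there, and compound 2 `CSc1cc(NCc2cccnc2)n2ncc(Br)c2n1` carries methylsulfanyl and gives 990 nM in the same test. Compound 4 `Brc1cnn2c(NCc3cccnc3)cc(-c3ccco3)nc12` has furan-2-yl in place of piperidin-3-yl on an aromatic carbon, next to the ring nitrogen (furan-2-yl in place of piperidin-3-yl on an aromatic carbon). Within the data shown here, two measured steps bear on this place: an 8.7-fold lower number from compound 1 to compound 3 (0.94 log units; beyond the scatter) and a 17-fold lower number from compound 2 to compound 3 (1.22 log units; beyond the scatter). Both reach the lower number with piperidin-3-yl, while a 1.9-fold higher number from compound 1 to compound 2 (0.28 log units; within the scatter) stays within the scatter. Among the measured compounds shown here, no measured compound carries furan-2-yl, so these steps offer only a rough guide. The step expected in this assay is therefore upward and modest, an estimated 5.0-fold higher number from compound 3 to compound 4 (0.70 log units; beyond the scatter) towards a weaker inhibitor. Compound 4 is expected at about 300 nM (80 nM to 1000 nM).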

Compound 4, half-maximal inhibitory concentration: 15200 nM
Estimate against measurement, compound 4: 51-fold (1.70 log units) below; measured number above the stated range.
By their numbers in this assay, from the lowest: compound 3; then compounds 1 and 2 (each within the scatter of the next); then compound 4.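

In this assay, furan-2-yl is the weakest of the four groups shown at this aromatic carbon: there is a 250-fold higher number from compound 3 to compound 4 (2.40 log units; beyond the scatter), and it also trails the two small groups, with a 29-fold higher number from compound 1 to compound 4 (1.47 log units; beyond the scatter) and a 15-fold higher number from compound 2 to compound 4 (1.19 log units; beyond the scatter). Within the data shown here, the position therefore tolerates far less than the earlier compounds suggested, since their widest gap was a 17-fold lower number from compound 2 to compound 3 (1.22 log units; beyond the scatter), and a second ring here does not by itself preserve the result seen with piperidin-3-yl. No evidence is available to explain the size of this loss.

The change swaps a six-membered non-aromatic ring with a hydrogen-bond donor for a five-membered aromatic ring without one, so the compounds shown cannot separate ring size, aromaticity and the donor. Cyclohexyl, phenyl or an open-chain amine at this place would pull these apart.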